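Arylpiperazine indole carboxamides: step from compound 2 to 3

The source may report more compounds than this note shows. Statements on the series, on what has been measured and on what is new or still open speak of the compounds shown alone.

Measured so far:
- compound 1 `COc1ccccc1N1CCN(CCCNC(=O)Cc2c[nH]c3ccccc23)CC1` gives 7.94 nM in an assay on isolated protein (Vas deferens, strain Sprague-Dawley) for antagonist activity at Alpha-1A adrenergic receptor (Rattus norvegicus), with a stated time of 20 min; on this read-out lower numbers stand for tighter binding and higher numbers for weaker binding
- compound 2 `COc1ccccc1N1CCN(CCCNC(=O)c2cc3cc(O)ccc3[nH]2)CC1` gives 55 nM in this assay

Compound 2 holds the highest number of the two measured in this assay; its nearest neighbour is compound 1, and the step of a 6.9-fold higher number from compound 1 to compound 2 (0.84 log units; beyond the scatter) lies beyond the scatter.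

Compound 3 `COc1ccccc1N1CCN(CCCNC(=O)c2cc3ccc(Br)cc3[nH]2)CC1` has not been measured. It differs from compound 2 in one place: 6-bromo-1H-indol-2-yl in place of 5-hydroxy-1H-indol-2-yl on a carbonyl carbon. Within the data shown here, no measured step isolates this exchange, since the only step recorded, a 6.9-fold higher number from compound 1 to compound 2 (0.84 log units; beyond the scatter), alters both the attachment of the indole and the substituent on it at once. That step is modest in size and bears on the present question only in showing that changes on the indole part of the shared core move the number by a moderate amount. The direction for compound 3 cannot be read from compound 1 and compound 2 alone.

Compound 3 is therefore expected to give roughly 30 nM in this assay, within 8 nM to 120 nM, which is an expected step of a 1.8-fold lower number from compound 2 to compound 3 (0.26 log units; within the scatter) and may fall within the scatter.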

Compound 3, dissociation constant: 69.2 nM
For compound 3 the middle estimate is 2.3-fold (0.36 log units) below the measured one; measured number inside the range.
By their numbers in this assay, from the lowest: compound 1; then compounds 2 and 3 (each within the scatter of the next).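

In this assay, the exchange of 5-hydroxy-1H-indol-2-yl for 6-bromo-1H-indol-2-yl on the carbonyl carbon gives a 1.3-fold higher number from compound 2 to compound 3 (0.10 log units; within the scatter), so at this place a change in both the substituent and its ring location, with a different count of hydrogen-bond donors and acceptors, leaves the number inside the scatter. With an 8.7-fold higher number from compound 1 to compound 3 (0.94 log units; beyond the scatter), compound 1 now stands beyond the scatter from both compound 2 and compound 3, and these two, with different substituents, carry the 1H-indol-2-yl attachment directly on the carbonyl carbon, though each step to them also changes the substituent along with the attachment. No measurement at hand offers an explanation for these numbers.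

An unsubstituted 1H-indol-2-yl group would show whether either substituent matters at all, while 5-bromo-1H-indol-2-yl and 6-hydroxy-1H-indol-2-yl would separate the identity of the substituent from its location. A (6-bromo-1H-indol-3-yl)methyl group on the same carbonyl carbon would leave open whether the number stays close to that of compound 1 or moves toward those of compound 2 and compound 3, and so would test the attachment apart from the substituent.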